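A few compounds are considered here, and "the series" means these few. Any claim that something is new, unique, unknown or untested is made for them only; others in the source may bear on it.

Compound 1 `Cc1nn(-c2nc(-c3ccc(Cl)c(Cl)c3)c(SC(C)C)s2)c(C(=O)O)c1-c1cccc(F)c1` gives 900 nM in a functional assay on BJAB cells (Homo sapiens) for antiproliferative activity, with a stated time of 4 days; a higher number here means that more compound is needed for the effect, a lower number that less compound is needed.
Compound 2 `Cc1nn(-c2nc(-c3ccc(Cl)c(Cl)c3)c(SC(C)C)s2)c(C(=O)O)c1-c1cncc(C#N)c1` gives 20000 nM in this assay.
Compound 3 `Cc1nn(-c2nc(-c3ccc(Cl)c(Cl)c3)c(SC(C)C)s2)c(C(=O)O)c1-c1ccc(Cl)cc1` gives 2500 nM in this assay.

All three share one core and differ only in the aromatic group attached to the five-membered ring with two nitrogen atoms. Compound 3 stands in the middle of the three numbers: the step of a 2.8-fold higher number from compound 1 to compound 3 (0.44 log units; beyond the scatter) separates it from compound 1, and the step of an 8.0-fold lower number from compound 2 to compound 3 (0.90 log units; beyond the scatter) separates it from compound 2, both beyond the scatter.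

Compound 4 `Cc1cccc(-c2c(C)nn(-c3nc(-c4ccc(Cl)c(Cl)c4)c(SC(C)C)s3)c2C(=O)O)c1` has not yet been measured. It differs from compound 3 in one place: 3-methylphenyl in place of 4-chlorophenyl on an aromatic carbon. Of the measured steps, a 2.8-fold higher number from compound 1 to compound 3 (0.44 log units; beyond the scatter) bears most on this change, since a 3-methylphenyl resembles the 3-fluorophenyl of compound 1 more closely than the 4-chlorophenyl of compound 3. The large step of a 22-fold higher number from compound 1 to compound 2 (1.35 log units; beyond the scatter) matters less here. Compound 4 keeps a six-membered aromatic ring of carbon only. A modest step in this assay is therefore expected, in the direction of needing less compound, roughly undoing the move from compound 1 to compound 3.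

Compound 4 is expected to give about 1200 nM, with a range from 400 nM to 4000 nM, which is estimated to mean a 2.1-fold lower number from compound 3 to compound 4 (0.32 log units; beyond the scatter).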

Compound 4, half-maximal effective concentration: 17000 nM
Estimate against measurement, compound 4: 14-fold (1.15 log units) below; the measured number lies above the stated range.
By their numbers in this assay, from the lowest: compound 1; then compound 3; then compounds 4 and 2 (each within the scatter of the next).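

In this assay, the exchange of fluoro for methyl on an aromatic carbon gives a 19-fold higher number from compound 1 to compound 4 (1.28 log units; beyond the scatter), so a single small substituent on this ring can change the number about as much as the switch to 5-cyanopyridin-3-yl did. The earlier compounds shown here left open the reading that an aromatic ring of carbon only keeps the number fairly low, but 3-methylphenyl in place of 4-chlorophenyl gives a 6.8-fold higher number from compound 3 to compound 4 (0.83 log units; beyond the scatter), even though both groups count the same heavy atoms and neither has a hydrogen-bond donor or acceptor. The 3-methylphenyl and 5-cyanopyridin-3-yl groups also cannot be told apart in this assay, with a 1.2-fold lower number from compound 2 to compound 4 (0.07 log units; within the scatter), so a high number here is not confined to the group that carries a ring nitrogen and a nitrile.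

From the compounds shown here alone, it remains open whether a plain phenyl, a methoxy group or an amine on this ring would bring the number closer to that of compound 1 or that of compound 4. No measurement shown here accounts for the gap between the methyl and fluoro compounds.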